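This account rests on a few compounds, and the source may have more. Where it says the series, first, only, none or still open, it means among the compounds named here.

In a functional assay on A549 cells (Homo sapiens) for inhibition, read by MTT assay, with a stated time of 72 h (a lower number here means a stronger inhibitor, a higher number a weaker inhibitor), three compounds have been measured:

- compound 1 `CNC(=O)CCCCCCCn1nc(-c2cnc3[nH]ccc3c2)c2c(N)ncnc21` gives 51000 nM
- compound 2 `Nc1nc2cc(-c3nn(CCCCCCCCCC(=O)NO)c4ncnc(N)c34)ccc2o1` gives > 50000 nM as a limit, not a number
- compound 3 `Nc1ncnc2c1c(-c1cnc3[nH]ccc3c1)nn2CCCCCCC(=O)NO` gives 50000 nM

Within the data shown here, compound 1 stands level with compound 3 in this assay, and no measured compound sits clearly apart from it. For compound 2 the reading is only a limit: the limit of > 50000 nM in this assay, at which 1 of the 3 values shown sits, is all it offers.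

The compound still to be measured is compound 4 `Nc1ncnc2c1c(-c1cnc3[nH]ccc3c1)nn2CCC(=O)NO`. Its difference from compound 1 is hydroxycarbamoyl in place of 5-(methylcarbamoyl)pentyl on a saturated chain carbon, two bonds along the chain from an aromatic nitrogen with hydroxycarbamoyl in place of 5-(methylcarbamoyl)pentyl on a saturated chain carbon, two bonds along the chain from an aromatic nitrogen.

Among the measured compounds shown here, one measured step bears on this change. Hydroxycarbamoyl also enters in a 1.0-fold lower number from compound 1 to compound 3 (0.01 log units; within the scatter) in place of (methylcarbamoyl)methyl, six bonds along the chain from an aromatic nitrogen, and that step lies within the scatter. Bringing in the same group therefore gives no reason to expect a real shift, although no measured compound carries it two bonds along the chain, so the expectation stays loose.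

The expected step is a 1.0-fold lower number from compound 1 to compound 4 (0.01 log units; within the scatter) and so nothing beyond the scatter. For compound 4 the estimate is 50000 nM with an expected range from 20000 nM to 100000 nM in this assay. Compound 4 may well give only a limit.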

Compound 4, half-maximal inhibitory concentration: > 150000 nM
Compound 4: no number, only a limit; the forecaster's own chance of this, stated with the estimate: 45%; middle value at least 3.0-fold (0.47 log units) away from the limit.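

In this assay compound 4 gives no number, only a limit: the limit of > 150000 nM in this assay, at which 1 of the 4 values shown sits. Hydroxycarbamoyl on a saturated chain carbon, two bonds along the chain from an aromatic nitrogen, brings an at least 2.9-fold higher number from compound 1 to compound 4 (0.46 log units; beyond the scatter), and in place of 4-(hydroxycarbamoyl)butyl it brings an at least 3.0-fold higher number from compound 3 to compound 4 (0.47 log units; beyond the scatter), whereas six bonds along the chain the same group had brought only a 1.0-fold lower number from compound 1 to compound 3 (0.01 log units; within the scatter). Among these compounds, the earlier compounds therefore gave a picture of a group that changes nothing, which holds six bonds along the chain but not two bonds along it, and since compound 4 gives a limit, the full size of both new steps stays unknown.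

The compounds shown leave open whether a carboxylic acid or a plain amide at the end of the same short chain would read as compound 4 does, and at which chain length between those of compound 4 and compound 3 the readings part. Compound 2 differs from the others in more than one place and gives only a limit, so it adds nothing on chain length: the limit of > 50000 nM in this assay, at which 1 of the 4 values shown sits.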